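Adding a Phenyl Ring to the Dichlorophenyl Sulfone

The source may hold more compounds than are shown below. What is called first, only, known or untested is meant among the compounds shown, and "the series" means these compounds.

Compound 1 `O=C(NC[C@@H](C(=O)O)S(=O)(=O)c1c(Cl)cccc1Cl)C1=NOC2(CCC(CNc3ncc[nH]3)CC2)C1` is one of three close relatives tested in a functional assay for antagonist activity at integrin alpha-5/beta-1 (Homo sapiens), read by ELISA; a lower number here means a stronger inhibitor, a higher number a weaker inhibitor. In this assay compound 1 gives 3000 nM, the second highest of the three numbers. Compound 2 `O=C(NC[C@@H](C(=O)O)S(=O)(=O)c1ccccc1)C1=NOC2(CCC(CNc3ncc[nH]3)CC2)C1` carries a plain phenyl on the sulfonyl sulfur and gives 4700 nM; the change is a 1.6-fold higher number from compound 1 to compound 2 (0.19 log units; within the scatter). Compound 3 `Cc1cc(C)c(S(=O)(=O)[C@@H](CNC(=O)C2=NOC3(CCC(CNc4ncc[nH]4)CC3)C2)C(=O)O)c(C)c1` carries a 2,4,6-trimethylphenyl on the sulfonyl sulfur and gives 1500 nM; here a 2.0-fold lower number from compound 1 to compound 3 (0.30 log units; within the scatter), while a 3.1-fold lower number from compound 2 to compound 3 (0.50 log units; beyond the scatter).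

Compound 4 `O=C(NC[C@@H](C(=O)O)S(=O)(=O)c1c(Cl)cc(-c2ccccc2)cc1Cl)C1=NOC2(CCC(CNc3ncc[nH]3)CC2)C1` differs from compound 1 in one place: phenyl in place of hydrogen on an aromatic carbon. Within the data shown here, no measured step adds a group at that position; the three measured steps only swap the whole ring on the sulfonyl sulfur, and they move the number modestly at most. The step from compound 1 to compound 4 in this assay is therefore expected to be small, in either direction. For compound 4 a value of 2000 nM is estimated, with a range from 500 nM to 8000 nM. That estimate means an expected step of a 1.5-fold lower number from compound 1 to compound 4 (0.18 log units; within the scatter).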

Compound 4, half-maximal inhibitory concentration: 310 nM
Compound 4: middle estimate off by 6.5-fold (0.81 log units), on the high side, and the stated range ends above it.
By their numbers in this assay, from the lowest: compound 4; then compounds 3, 1 and 2 (each within the scatter of the next, the first and the last beyond it).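

In this assay, phenyl in place of hydrogen on the aromatic carbon meta to the two chloro groups gives a 9.7-fold lower number from compound 1 to compound 4 (0.99 log units; beyond the scatter). That is a larger move than any swap of the whole ring on the sulfonyl sulfur, the largest of which was a 3.1-fold lower number from compound 2 to compound 3 (0.50 log units; beyond the scatter), so a substituent at this one carbon can shift the number more than those swaps did. The data shown offer no measured explanation for this gain.

On these data alone, it remains open whether the gain requires an aromatic ring at this carbon, or whether a smaller group such as a methoxy or an amine would also give it. As far as these compounds go, it is also open whether the same phenyl would have a similar effect without the two chloro groups, as on the plain phenyl ring of compound 2.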